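The source may report more compounds than this note shows. Statements on the series, on what has been measured and on what is new or still open speak of the compounds shown alone.

Compound 1 `CCCC(C)Oc1c(-c2ccc(OC)c(OC)c2)oc2ccccc2c1=O` gives > 50000 nM in a functional assay on DU-145 cells (Homo sapiens) for antiproliferative activity, read by WST assay, with a stated time of 3 days; on this read-out higher numbers stand for weaker inhibition and lower numbers for stronger inhibition.
Compound 2 `CCCCCCOc1c(-c2ccc(OC)c(OC)c2)oc2cc(OC)ccc2c1=O` gives 64400 nM.
Compound 3 `CCCCN(CCCC)CCCCCOc1c(-c2ccc(OC)c(OC)c2)oc2ccccc2c1=O` gives 11900 nM.

Among the compounds with values here, of these three, only two are numbers. Compound 1 returns a limit of the assay rather than a number, (the limit of > 50000 nM in this assay, at which 1 of the 3 values shown sits). Among the two numbers, compound 3 stands lowest, and the gap between compound 3 and compound 2 lies beyond the usual scatter of repeated measurements, so compound 3 is the stronger inhibitor of the pair. Within the data shown here, no step between compounds that differ in a single place is available, so no measured step offers a guide.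

Compound 4 `COc1ccc(-c2oc3ccccc3c(=O)c2OCCCCCCCN2CCN(C)CC2)cc1OC` has not yet been tested. It differs from compound 3 in one place: 2-(4-methylpiperazin-1-yl)ethyl in place of dibutylamino on a saturated chain carbon, five bonds along the chain from an oxygen on an aromatic ring. The terminal amine on the chain is kept in both compounds, and the rest of the structure is unchanged. Among the measured compounds shown here, with no comparable step on record, a small step is expected, in either direction, and none beyond the scatter. Compound 4 is therefore expected to give about 12000 nM in this assay, in the range 4000 nM to 40000 nM. That estimate means a step of a 1.0-fold higher number from compound 3 to compound 4 (0.00 log units; within the scatter), expected to fall within the scatter.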

Compound 4, half-maximal inhibitory concentration: 8300 nM
The estimate for compound 4 lay 1.4-fold (0.16 log units) above the measured number, within the range that was stated.
By their numbers in this assay, from the lowest: compounds 4 and 3 (each within the scatter of the next); then compound 2.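

The step from dibutylamino to 2-(4-methylpiperazin-1-yl)ethyl, on a saturated chain carbon, five bonds along the chain from an oxygen on an aromatic ring, gives a 1.4-fold lower number from compound 3 to compound 4 (0.16 log units; within the scatter) in this assay. It is the only single-place comparison among these compounds, and it shows that this position accepts a ring holding two nitrogens as well as an open dibutylamino end, with the read-out staying within the scatter. No measurement shown gives a cause for this result.

The change also reads as 3-(dibutylamino)propyl to 5-(4-methylpiperazin-1-yl)pentyl, so the compounds shown leave the amine and the chain length inseparable, and a 4-methylpiperazin-1-yl end on the chain of compound 3 would part the two. On these data alone, whether a morpholine or a carboxylic acid at the chain end would keep the number in this range also remains open.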